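Sulfonamide aryl variation on the shared core

This account rests on a few compounds, and the source may have more. Where it says the series, first, only, none or still open, it means among the compounds named here.

Compound 2 `COc1ccccc1NS(=O)(=O)c1ccc(N2CCNC2=O)cc1` gives 550 nM in a functional assay on HT-29 cells (Homo sapiens) for antiproliferative activity, read by sulforhodamine B assay, with a stated time of 48 h; a higher number here means a weaker inhibitor, a lower number a stronger inhibitor. Compound 1 `CCCCCc1ccc(NS(=O)(=O)c2ccc(N3CCNC3=O)cc2)cc1` gives 990 nM in this assay, and the two numbers sit within the scatter of each other, so no order between compound 1 and compound 2 can be read. Compound 3 `CC(C)(C)c1ccc(NS(=O)(=O)c2ccc(N3CCNC3=O)cc2)cc1` reaches only a limit in this assay, > 1000 nM, and no number is known for it. Among the measured compounds shown here, the one measured step on this series, a number no lower from compound 1 to compound 3 (the limit leaves the size open), touches only the alkyl group on the aromatic carbon and its size stays open because of the limit of > 1000 nM in this assay, at which 1 of the 3 values shown sits.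

Compound 4 `O=C1NCCN1c1ccc(S(=O)(=O)Nc2cccc(Cl)c2)cc1` is not yet measured. It differs from compound 2 by 3-chlorophenyl in place of 2-methoxyphenyl on a sulfonamide nitrogen. For the measured compounds named here, no measured step touches the sulfonamide aryl ring in this way, so nothing speaks for a shift in either direction beyond the scatter, and the expectation for compound 4 rests on compound 2 alone. The step from compound 2 to compound 4 is therefore expected to be a 1.2-fold higher number from compound 2 to compound 4 (0.07 log units; within the scatter), that is, no change beyond the scatter. Compound 4 is expected to give 650 nM in this assay, with a range from 250 nM to 1700 nM.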

Compound 4, half-maximal inhibitory concentration: 55 nM
Compound 4: middle estimate off by 12-fold (1.07 log units), on the high side; the measured number lies below the stated range.
By their numbers in this assay, from the lowest: compound 4; then compounds 2 and 1 (each within the scatter of the next). At a limit, above all of these: compound 3.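

Among the compounds shown here, the aryl group on the sulfonamide nitrogen is a place where the number can move: in this assay the change gives a 10-fold lower number from compound 2 to compound 4 (1.00 log units; beyond the scatter) and is the first step that lies beyond the scatter. For the compounds shown here, the earlier compounds offered only two values within the scatter of each other and a limit, so they showed no readable effect of any change on the shared core. The step replaces 2-methoxyphenyl with 3-chlorophenyl, so the loss of the methoxy group, the arrival of the chlorine and the different placing on the ring all arrive together, and no measurement shown bears on the cause of the step.

Open, going by these compounds, is how an unsubstituted phenyl, a 3-methoxyphenyl or a 3-fluorophenyl on the sulfonamide nitrogen would compare with compound 4, which would separate these contributions. The step from compound 1 to compound 3 cannot be read, since compound 3 stands at a limit, so the alkyl groups on the aromatic carbon remain unordered.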